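Replacing a Cyclohexyl with a Benzyl on the Ring Nitrogen

The source may report more compounds than this note shows. Statements on the series, on what has been measured and on what is new or still open speak of the compounds shown alone.

Of the compounds shown here, three of a shared core have been measured in a functional assay on MDA-MB-231 cells (Homo sapiens) for inhibition, read by sulforhodamine B assay, with a stated time of 48 h, tested at 10 uM; a lower number here means less inhibition, a higher number more inhibition at the concentration tested (going by the name of the read-out). Compound 1 `c1ccc(-c2cn3ccnc3c(-c3ccc4ncn(C5CCCCC5)c4c3)n2)cc1` gives 41.5%, compound 2 `Fc1ccccc1-c1cn2ccnc2c(-c2ccc3ncn(C4CCCCC4)c3c2)n1` gives 21.3%, and compound 3 `c1cn2cc(-c3ccc4c(c3)ncn4C3CCCCC3)nc(-c3ccc4ncn(C5CCCCC5)c4c3)c2n1` gives 28.9%. Among the measured compounds shown here, the only single-point step among them is a number 20.2 percentage points lower from compound 1 to compound 2 (beyond the scatter). Compound 3 stands second highest of the three numbers: its value and that of compound 2 lie within the scatter of each other, whereas compound 1 sits above compound 3 by a margin beyond the scatter.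

Compound 4 `c1ccc(Cn2cnc3ccc(-c4nc(-c5ccc6c(c5)ncn6C5CCCCC5)cn5ccnc45)cc32)cc1` differs from compound 3 in one place, (benzyl in place of cyclohexyl on an aromatic nitrogen). For the measured compounds named here, no measured step concerns this change: the step from compound 1 to compound 2 touches a hydrogen on an aromatic carbon, not the substituent on the aromatic nitrogen of the fused five-membered ring, and both cyclohexyl and benzyl carry no donors and no acceptors. Going by the values given here, the only guide is therefore the value of compound 3 itself, and one may expect a step no larger than the scatter in either direction. Accordingly, compound 4 is estimated at 29%, between 12% and 46%, which implies an expected step of a number 0.1 percentage points higher from compound 3 to compound 4 (within the scatter).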

Compound 4, a percentage reported as inhibition, at one concentration (the size of the read-out at that concentration, not a potency): -70.1%
Beside the measured number, compound 4's estimate is 99.1 percentage points above it; measured number outside the range, below it.
By their numbers in this assay, from the lowest: compound 4; then compounds 2 and 3 (each within the scatter of the next); then compound 1.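

In this assay, putting benzyl in place of cyclohexyl on the aromatic nitrogen gives a number 99 percentage points lower from compound 3 to compound 4 (beyond the scatter), so this position responds strongly to the group it carries, even though neither group has a hydrogen-bond donor, a hydrogen-bond acceptor or a net charge. Among the compounds shown here, compound 4 gives -70.1%, a negative number on a read-out reported as inhibition, and it is the only one of the four compounds whose value falls below zero. Nothing available explains this step or what the negative value reflects in the cells.

This single pair cannot show whether the step belongs to the aromatic ring of benzyl or to the way that ring is held on the nitrogen; a phenyl group attached directly or a phenethyl chain at the same nitrogen would begin to separate the two. It also leaves open whether the same exchange would matter as much on the core of compound 1, or with a small group such as methyl on that nitrogen.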